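A few compounds are considered here, and "the series" means these few. Any claim that something is new, unique, unknown or untested is made for them only; others in the source may bear on it.

Compound 2 `Cc1cc(C)c(CN2CCc3c(Cl)cc(-c4c(C)n[nH]c4C)c(Cl)c3C2=O)c(=O)[nH]1` gives 82 nM in an assay on Sf9 cells for inhibition of histone-lysine N-methyltransferase EZH2 variant Y641N (Homo sapiens), read by scintillation counting, with a stated time of 60 min, in the presence of a further agent that is not named here (on this read-out lower numbers stand for stronger inhibition and higher numbers for weaker inhibition), the lowest of the two numbers seen so far; compound 1 `Cc1cc(C)c(CN2CCc3c(Cl)cc(-c4cn[nH]c4)c(Cl)c3C2=O)c(=O)[nH]1` gives 270 nM in this assay. Among the measured compounds shown here, the one measured step, a 3.3-fold lower number from compound 1 to compound 2 (0.52 log units; beyond the scatter), is the only one that bears on the change at hand. Compound 3 `Cc1cc(C)c(CN2CCc3c(Cl)cc(-c4cn[nH]c4C)c(Cl)c3C2=O)c(=O)[nH]1` differs from compound 2 by hydrogen in place of methyl on an aromatic carbon, undoing half of that earlier change. Because that step a 3.3-fold lower number from compound 1 to compound 2 (0.52 log units; beyond the scatter) corresponded to two added methyl groups, removing one of them is expected to give a 1.7-fold higher number from compound 2 to compound 3 (0.23 log units; within the scatter), a modest rise. Compound 3 is therefore estimated at 140 nM, within 70 nM to 300 nM.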

Compound 3, half-maximal inhibitory concentration: 110 nM
The estimate for compound 3 lay 1.3-fold (0.10 log units) above the measured number; the range from low to high includes it.
By their numbers in this assay, from the lowest: compounds 2 and 3 (each within the scatter of the next); then compound 1.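

Going from 3,5-dimethyl-1H-pyrazol-4-yl to 5-methyl-1H-pyrazol-4-yl leaves the two compounds indistinguishable in this assay, with a 1.3-fold higher number from compound 2 to compound 3 (0.13 log units; within the scatter), so the second methyl adds nothing that can be resolved here. A single methyl is already enough to separate compound 3 from the unsubstituted pyrazole, with a 2.5-fold lower number from compound 1 to compound 3 (0.39 log units; beyond the scatter), a step beyond the scatter. Going by these compounds, whether a larger group on this carbon, such as ethyl or an amine, would hold this level remains open. No measurement here explains why one methyl matters.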